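Swapping a sulfonamide for a methoxy group on the amide nitrogen

This account rests on a few compounds, and the source may have more. Where it says the series, first, only, none or still open, it means among the compounds named here.

Three compounds share one core and differ only in the ring attached to the amide-type nitrogen. Compound 1 `COc1ccc(Oc2ccc([N+](=O)[O-])cc2C(=O)Nc2ccccc2S(N)(=O)=O)cc1` shows "no significant activity" (no number reported) in a functional assay (Homo sapiens) for inhibition, using a membrane potential dye, in the presence of a further agent that is not named here; on this read-out higher numbers stand for weaker inhibition and lower numbers for stronger inhibition. Compound 2 `COc1ccc(Oc2ccc([N+](=O)[O-])cc2C(=O)Nc2ccc(S(N)(=O)=O)cc2)cc1` gives 1800 nM in this assay, and compound 3 `COc1ccc(Oc2ccc([N+](=O)[O-])cc2C(=O)Nc2cccc(S(N)(=O)=O)c2)cc1` gives 9900 nM. Compound 3 therefore stands at the highest, that is weakest, of the two numbers reported, and the step of a 5.5-fold higher number from compound 2 to compound 3 (0.74 log units; beyond the scatter) shows how far it lies from compound 2.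

Compound 4 `COc1ccc(NC(=O)c2cc([N+](=O)[O-])ccc2Oc2ccc(OC)cc2)cc1` is the next compound in this series. Its change from compound 3 is 4-methoxyphenyl in place of 3-sulfamoylphenyl on an amide-type nitrogen. Within the data shown here, the only measured step moves the same sulfamoyl group around the ring; no measured step removes it or brings in a methoxy group, so there is no direct guide. Since the two sulfamoyl positions already span a 5.5-fold higher number from compound 2 to compound 3 (0.74 log units; beyond the scatter), and compound 1 with a third position shows no activity, a weaker result seems more likely than a stronger one for compound 4.

The expected step for compound 4 is a 2.0-fold higher number from compound 3 to compound 4 (0.31 log units; beyond the scatter), with a wide range. Compound 4 is estimated at 20000 nM, between 4000 nM and 100000 nM.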

Compound 4, half-maximal inhibitory concentration: 3400 nM
The estimate for compound 4 lay 5.9-fold (0.77 log units) above the measured number; measured number below the stated range.
By their numbers in this assay, from the lowest: compounds 2 and 4 (each within the scatter of the next); then compound 3.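

Replacing the 3-sulfamoylphenyl ring on the amide-type nitrogen with 4-methoxyphenyl gives a modest gain, seen as a 2.9-fold lower number from compound 3 to compound 4 (0.46 log units; beyond the scatter), so this position does not depend on keeping a sulfamoyl group for a measurable number in this series. Set against the compound that differs only in methoxy in place of sulfamoyl on an aromatic carbon, the result is a 1.9-fold higher number from compound 2 to compound 4 (0.28 log units; within the scatter), which means that compound 2 and compound 4 cannot be told apart here, even though the groups that differ between them are quite unlike one another by name and by their counted atoms. Nothing shown here accounts for why these two different groups give readings that cannot be separated.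

Going by these compounds, whether the methoxy group is as sensitive to its place on the ring as the sulfamoyl group, whose three placements in compound 1, compound 2 and compound 3 gave clearly different outcomes, remains open. On these data alone, it is also open how other groups on the same ring, such as an amine, a carboxylic acid or a longer ether chain, would compare with methoxy and sulfamoyl.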